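Pyridinyl for Methoxyphenyl on the Isatin Core

This account rests on a few compounds, and the source may have more. Where it says the series, first, only, none or still open, it means among the compounds named here.

Measured compounds in a functional assay on K562 cells (Homo sapiens) for antiproliferative activity, read by MTT assay, with a stated time of 48 h; a higher number here means a weaker inhibitor, a lower number a stronger inhibitor:
compound 1 `COc1ccc(-c2ccc3c(c2)C(=O)C(=O)N3Cc2ccc(Cl)cc2)cc1` gives 350 nM
compound 2 `COc1ccc(-c2ccc3c(c2)C(=O)C(=O)N3Cc2ccc(Br)cc2)cc1` gives 100 nM
compound 3 `COc1ccc(CN2C(=O)C(=O)c3cc(-c4ccc(OC)cc4)ccc32)cc1` gives 30 nM

Compound 3 stands lowest of the three, with a 3.3-fold lower number from compound 2 to compound 3 (0.52 log units; beyond the scatter) and a 12-fold lower number from compound 1 to compound 3 (1.07 log units; beyond the scatter) separating it from the others; the remaining measured step is a 3.5-fold lower number from compound 1 to compound 2 (0.54 log units; beyond the scatter). All three steps concern only the group on the benzyl ring attached to the ring nitrogen, and none touches the aryl group on the fused core.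

Compound 4 `COc1ccc(CN2C(=O)C(=O)c3cc(-c4ccncc4)ccc32)cc1` differs from compound 3 elsewhere: pyridin-4-yl in place of 4-methoxyphenyl on an aromatic carbon. Among the compounds with values here, no measured pair shows a change at this place, so the three steps give no direct guide to its size or direction. With nothing to anchor the step, a modest rise in the number is expected, since the whole measured range spans a factor that the new change might plausibly occupy in either direction. Compound 4 is therefore estimated at 80 nM, within 20 nM to 400 nM, meaning an expected step of a 2.7-fold higher number from compound 3 to compound 4 (0.43 log units; beyond the scatter).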

Compound 4, half-maximal inhibitory concentration: 40 nM
Compound 4: the middle estimate sits 2.0-fold (0.30 log units) above what was measured; the range from low to high includes it.
By their numbers in this assay, from the lowest: compounds 3 and 4 (each within the scatter of the next); then compound 2; then compound 1.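

In this assay, the step at the aryl group on the shared core reads a 1.3-fold higher number from compound 3 to compound 4 (0.12 log units; within the scatter) and so compound 3 and compound 4 cannot be told apart, even though pyridin-4-yl brings a ring nitrogen and the methoxy group of 4-methoxyphenyl is gone. Within the data shown here, the earlier steps all concerned the group on the benzyl ring and all lay beyond the scatter, whereas this pair gives the first reading at this second place, for one exchange on one benzyl group. Nothing measured here bears on the reason for this result.

As far as these compounds go, whether pyridin-4-yl would read the same alongside the chloro or bromo benzyl groups of compound 1 and compound 2 remains open. So does what a morpholine, a carboxylic acid or a primary amine would do at this place on the core.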